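The source may hold more compounds than are shown below. What is called first, only, known or untested is meant among the compounds shown, and "the series" means these compounds.

In a functional assay on HL-60 cells (Homo sapiens) for cytotoxicity, read by luminescence and CellTiter-Glo, with a stated time of 3 days (on this read-out lower numbers stand for stronger inhibition and higher numbers for weaker inhibition), compound 1 (`COc1ccc(O)c(C(=O)Nc2ccc(C#N)cc2)c1`) shows only a limit of the assay, > 10000 nM. Going by the values given here, compound 2 (`N#Cc1ccc(NC(=O)c2cc(-c3cccnc3)ccc2O)cc1`) gives 7960 nM, the only true number so far, so it cannot yet be ranked against any other measured value. The next compound, compound 3 (`N#Cc1ccc(NC(=O)c2cc(Cl)ccc2O)cc1`), carries chloro in place of pyridin-3-yl on an aromatic carbon, para to a hydroxy group: chloro in place of pyridin-3-yl on an aromatic carbon. Among the compounds with values here, one measured step bears on this place, the exchange of methoxy for pyridin-3-yl, and it is an at least 1.2-fold lower number from compound 1 to compound 2 (0.09 log units; that floor lies within the scatter). Within the data shown here, as that step starts from a limit, it gives a floor and no true size, and no compound with chloro has been measured. Any forecast for this assay is therefore loose, and only a small move towards a lower number is expected, with a reading at the limit still possible. The expected change is a 1.8-fold lower number from compound 2 to compound 3 (0.25 log units; within the scatter). For compound 3 the estimated value is 4500 nM, with an expected range from 1000 nM to 15000 nM.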

Compound 3, half-maximal inhibitory concentration: 700 nM
Compound 3: the middle estimate sits 6.4-fold (0.81 log units) above what was measured; measured number outside the range, below it.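

At this position, para to a hydroxy group, the earlier pair had given only a floor within the scatter, whereas the exchange of pyridin-3-yl for chloro gives a clear and large move in this assay: an 11-fold lower number from compound 2 to compound 3 (1.06 log units; beyond the scatter). Chloro in place of methoxy at the same position also gives a large move, an at least 14-fold lower number from compound 1 to compound 3 (1.15 log units; beyond the scatter), so compound 3 has the lowest number of the three compounds, and its steps to both others lie beyond the scatter. Compound 1 stands at a limit of the assay, so this second step is a floor and not a true size: the limit of > 10000 nM in this assay, at which 1 of the 3 values shown sits.

Whether the drop in the number belongs to chloro itself remains open, as the compounds shown do not say how bromo, fluoro, methyl or an amine would read at this position. On these data alone, the nitrile and the hydroxy group are the same in all three compounds, so their part in the read-out also remains unknown, and so does whether the effect of chloro would hold with either of them replaced.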